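Methylsulfanyl versus sulfanyl on a fused triazine core

A few compounds are considered here, and "the series" means these few. Any claim that something is new, unique, unknown or untested is made for them only; others in the source may bear on it.

Three measured compounds and one to be measured. Compound 1 `COCc1ncc2cnnc(SC)n12` and compound 2 `COCc1ncc2cnnc(S)n12` share a core; compound 3 `Cc1nnc(S)n2c(C)nc(C)c12` and compound 4 `CSc1nnc(C)c2c(C)nc(C)n12` share another, and the difference between the two cores is not broken down here. In a functional assay for inhibition, with Homo sapiens as the target (a higher number here means a weaker inhibitor, a lower number a stronger inhibitor), compound 1 gives only a limit, > 48000 nM. In this assay compound 2 gives only a limit, > 48000 nM. In this assay compound 3 gives only a limit, > 48000 nM. The change methyl in place of hydrogen on a sulfur gives a step that the two limits leave unreadable from compound 2 to compound 1, unreadable because of the limit of > 48000 nM in this assay, at which 3 of the 3 values shown sit. The change to compound 4, (methyl in place of hydrogen on a sulfur), is the same change at the same kind of place. Within the data shown here, no measured step is readable, so the step from compound 3 to compound 4 in this assay is expected at a step that the limit leaves unreadable from compound 3 to compound 4, resting only on (the limit of > 48000 nM in this assay, at which 3 of the 3 values shown sit). Compound 4 is therefore expected to give 60000 nM, most likely again reported as a limit.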

Compound 4, half-maximal inhibitory concentration: > 48000 nM
Compound 4: no number, only a limit; the forecaster's own chance of this, stated with the estimate: 85%; the middle value does not contradict the limit.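

No step can be read from compound 3 to compound 4 in this assay, since both give only a limit: the limit of > 48000 nM in this assay, at which 4 of the 4 values shown sit.

The compounds shown leave open how large the change from sulfanyl to methylsulfanyl is on either core.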